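A few compounds are considered here, and "the series" means these few. Any claim that something is new, unique, unknown or untested is made for them only; others in the source may bear on it.

The pair of measured compounds share one core. Compound 1 `Cc1cc(Nc2cc(-c3ccccc3)[nH]n2)n2nc(SCc3ccccc3Br)nc2n1` carries a (2-bromobenzyl)sulfanyl group, and in a functional assay on MCF7 cells (Homo sapiens) for inhibition, read by MTT assay, with a stated time of 72 h (a lower number here means a stronger inhibitor, a higher number a weaker inhibitor), compound 1 gives 3020 nM. Compound 2 `Cc1cc(Nc2ccn(Cc3csc4ccc(Cl)cc34)n2)n2nc(SCc3ccc(Br)cc3)nc2n1` is built differently on both sides of the core, and in this assay compound 2 gives 2570 nM. Compound 1 has the higher of these two numbers, but the gap to compound 2 lies within the scatter, so the two cannot be told apart on these data.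

The step under consideration leads from compound 1 to compound 3 `Cc1cc(Nc2cc(-c3ccccc3)[nH]n2)n2nc(SCC3CC3)nc2n1`, which has not yet been measured. The change is cyclopropyl in place of 2-bromophenyl on a saturated chain carbon bound to a sulfur. Among the measured compounds shown here, nothing in the measured set isolates this kind of change, so no measured step can anchor it. With the 2-bromophenyl ring leaving and only a cyclopropyl entering, a modest loss in this assay is expected, of a size around a 1.8-fold higher number from compound 1 to compound 3 (0.26 log units; within the scatter), though a result within the scatter of compound 1 would not surprise. Compound 3 is therefore estimated at 5500 nM in this assay, with a range from 2000 nM to 16000 nM.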

Compound 3, half-maximal inhibitory concentration: > 50000 nM
Compound 3 was reported as a limit; the forecaster's own chance of this, stated with the estimate: 15%; middle value at least 9.0-fold (0.95 log units) away from the limit.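

In this assay compound 3 gives > 50000 nM and this is a limit of the assay, not a number. Cyclopropyl in place of 2-bromophenyl on a saturated chain carbon bound to a sulfur gives an at least 16-fold higher number from compound 1 to compound 3 (1.21 log units; beyond the scatter) and so shows, as the earlier pair could not, that activity in this assay is sensitive to the group at this place. The true size of this step stays unknown, and it can only be read as a lower bound, because compound 3 sits at the limit of the assay: the limit of > 50000 nM in this assay, at which 1 of the 3 values shown sits.

What the compounds shown leave open is which part of the change matters, as the exchange removes the bromine and swaps the six-membered aromatic ring for the three-membered ring in a single step, so the two cannot be separated here. A plain benzyl group would set the ring apart from the bromine, a longer chain such as n-butyl would test a ring-free group at this place, and compound 2 cannot settle the question, as it differs from compound 1 on both sides of the core.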